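This account rests on a few compounds, and the source may have more. Where it says the series, first, only, none or still open, it means among the compounds named here.

Working notes on the series. Compound 1 `COc1cc(-c2nn(-c3cccc(NC(=O)c4cccc(C(F)(F)F)c4)c3)cc2-c2ccncc2)ccc1Cl` returns only a limit in a functional assay on MCF7 cells (Homo sapiens) for inhibition, read by sulforhodamine B assay, with a stated time of 48 h (a higher number here means a weaker inhibitor of growth, a lower number a stronger inhibitor of growth), namely > 50000 nM (the limit of > 50000 nM in this assay, at which 1 of the 2 values shown sits). Within the data shown here, compound 2 `COc1cc(-c2nn(-c3cccc(NC(=O)Nc4cccc(C(F)(F)F)c4)c3)cc2-c2ccncc2)ccc1Cl` gives 7720 nM in this assay, the single actual number in the set. Among the measured compounds shown here, the only measured step is an at least 6.4-fold lower number from compound 1 to compound 2 (0.81 log units; beyond the scatter). Compound 3 `COc1cc(-c2nn(-c3cccc(NC(=O)c4ccc(Cl)c(C(F)(F)F)c4)c3)cc2-c2ccncc2)ccc1Cl` differs from compound 2 by 4-chloro-3-(trifluoromethyl)phenyl in place of (3-(trifluoromethyl)phenyl)amino on a carbonyl carbon, which brings the carbonyl back to the amide type seen in compound 1. Undoing that measured step points to a rise in this assay of similar size, with a fair chance of another limit. Compound 3 is therefore expected near 40000 nM (range 10000 nM to 100000 nM), an estimated step of a 5.2-fold higher number from compound 2 to compound 3 (0.71 log units; beyond the scatter).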

Compound 3, concentration for total growth inhibition: > 32500 nM
Compound 3 ended at the assay's limit (the forecaster's own chance of this, stated with the estimate: 55%); the middle value is on the limit's open side.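

Setting 4-chloro-3-(trifluoromethyl)phenyl in place of (3-(trifluoromethyl)phenyl)amino on this carbonyl carbon gives an at least 4.2-fold higher number from compound 2 to compound 3 (0.62 log units; beyond the scatter). Among these compounds, a second amide-type compound thus stays limit-bound in this assay, now with chloro on the aromatic ring, and compound 2 remains the only one with an actual number. The values of compound 1 and compound 3 are both limits, so the step between them cannot be read.

Going by these compounds, the effect of chloro on the amino-linked compound 2 remains open. So does how a carboxylic acid or a morpholine in place of trifluoromethyl would read in this assay.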